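The compounds below may be only part of what the source reports. "The series", "measured", "known", "first", "only" and "open" are said of these compounds alone.

Working notes on the series. Compound 1 `N#Cc1c(-c2ccc3c(ccn3[C@H]3CC[C@H](O)CC3)c2)ccn2c(CC(F)(F)F)cnc12` in a functional assay on CHO cells for agonist activity at metabotropic glutamate receptor 2 (Homo sapiens) (a higher number here means a larger maximal response, a lower number a smaller maximal response), gives 237%. Compound 2 `Cn1ccc2cc(-c3ccn4c(CC(F)(F)F)cnc4c3C#N)ccc21` gives 154% in this assay, the lower of the two numbers. Going by the values given here, the single recorded step bears directly on the present case: a number 83 percentage points lower from compound 1 to compound 2 (beyond the scatter). Compound 3 `N#Cc1c(-c2ccc3c(ccn3C3CCOCC3)c2)ccn2c(CC(F)(F)F)cnc12` differs from compound 2 in one place (oxan-4-yl in place of methyl on an aromatic nitrogen); oxan-4-yl, like 4-hydroxycyclohexyl, is a six-membered non-aromatic ring carrying a hydrogen-bond acceptor. An upward step is therefore expected, a number 56 percentage points higher from compound 2 to compound 3 (beyond the scatter), recovering much of the response seen with compound 1. Compound 3 is estimated at 210%, range 160% to 260%.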

Compound 3, largest response reached (Emax), in percent of the reference or control that the assay uses: 442%
Compound 3: middle estimate off by 232 percentage points, on the low side, and the stated range ends below it.
By their numbers in this assay, from the lowest: compound 2; then compound 1; then compound 3.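

In this assay, a six-membered non-aromatic ring on the aromatic nitrogen does not by itself fix the maximal response: oxan-4-yl in place of methyl gives a number 288 percentage points higher from compound 2 to compound 3 (beyond the scatter), while oxan-4-yl in place of 4-hydroxycyclohexyl still gives a number 205 percentage points higher from compound 1 to compound 3 (beyond the scatter). At this position, the identity of the ring therefore matters as well as its presence. Nothing at hand accounts for the difference between the two rings. Still open, going by these compounds, is whether piperidin-4-yl, with a ring nitrogen in place of the oxygen, or an open 2-methoxyethyl chain would keep the response of compound 3.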